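Trimming a methyl from the aryl group of compound 2

A few compounds are considered here, and "the series" means these few. Any claim that something is new, unique, unknown or untested is made for them only; others in the source may bear on it.

Of the compounds shown here, two of a shared core have been measured in a functional assay on Ehrlich cells (Mus musculus) for cytotoxicity, tested at 50 ug/mL; on this read-out higher numbers stand for a stronger effect at the one concentration tested and lower numbers for a weaker effect. Compound 1 `COc1cc(N2C(N)=C(C#N)C(c3c(OC)ccc4ccccc34)C3=C2CC(C)(C)CC3=O)cc(OC)c1OC` carries a 2-methoxynaphthalen-1-yl group on a saturated ring carbon, and in this assay compound 1 gives 10%. Compound 2 `COc1cc(N2C(N)=C(C#N)C(c3ccc(C)cc3)C3=C2CC(C)(C)CC3=O)cc(OC)c1OC` carries 4-methylphenyl in that place, and in this assay compound 2 gives 60%. Within the data shown here, the one measured step reads a number 50 percentage points higher from compound 1 to compound 2 (beyond the scatter), and compound 2 therefore stands highest of the two numbers, with compound 1 as its nearest neighbour.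

Compound 3 `COc1cc(N2C(N)=C(C#N)C(c3ccccc3)C3=C2CC(C)(C)CC3=O)cc(OC)c1OC` differs from compound 2 as follows: hydrogen in place of methyl on an aromatic carbon. Among the measured compounds shown here, no measured step bears directly on this change; the only step available exchanges the whole aryl group rather than one methyl, and it was large. A single methyl leaving an aromatic carbon is a smaller alteration than that, so a step of modest size, or none beyond the scatter, is expected, most plausibly downward, since the measured sequence in this assay places the smaller aryl group higher but gives no guide for a still smaller one. Compound 3 is therefore estimated at 45%, within 20% to 70%, meaning an expected step of a number 15 percentage points lower from compound 2 to compound 3 (beyond the scatter).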

Compound 3, a percentage reported as activity, at one concentration (the size of the read-out at that concentration, not a potency): 8%
Compound 3: the middle estimate sits 37 percentage points above what was measured; the measured number lies below the stated range.
By their numbers in this assay, from the lowest: compounds 3 and 1 (each within the scatter of the next); then compound 2.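

In this assay, the methyl on an aromatic carbon para to a large group proves to be no minor detail: replacing it with hydrogen gives a number 52 percentage points lower from compound 2 to compound 3 (beyond the scatter), a step as large as the earlier exchange of the whole aryl group. The exchange of 2-methoxynaphthalen-1-yl for phenyl gives a number 2 percentage points lower from compound 1 to compound 3 (within the scatter), so the two aryl groups cannot be told apart on this read-out, and among these three compounds only the 4-methylphenyl group of compound 2 stands apart. The data offer no explanation of why a single methyl should matter this much.

From the compounds shown here alone, whether the methyl itself is required remains open, since it is unknown whether an ethyl group, a methoxy group or a chlorine atom on the same aromatic carbon would keep the read-out with compound 2 or leave it with compound 3. Each compound is described at only one concentration. These numbers also leave their potencies unresolved, and it is unclear whether the large step would hold at other concentrations.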